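Aryl change on the carbonyl carbon: compound 2 to compound 3

This account rests on a few compounds, and the source may have more. Where it says the series, first, only, none or still open, it means among the compounds named here.

Within the data shown here, compound 2 `COc1ccc(C(=O)/C=C/c2cc(-c3cc(OC)c(OC)c(OC)c3)n[nH]2)cc1OC` is the only member of the set with a numeric result: in a functional assay on SW-620 cells (Homo sapiens) for inhibition, read by sulforhodamine B assay, with a stated time of 48 h (on this read-out higher numbers stand for lower toxicity in this test and lower numbers for higher toxicity in this test), compound 2 gives 6550 nM. Compound 1 `COc1cc(-c2cc(/C=C/C(=O)c3ccc(N)cc3)[nH]n2)cc(OC)c1OC` reaches only a limit of the assay, > 100000 nM in this assay, and no number. Among the measured compounds shown here, the single measured step, an at least 15-fold lower number from compound 1 to compound 2 (1.18 log units; beyond the scatter), rests on that limit of > 100000 nM in this assay, at which 1 of the 2 values shown sits, at one end, so its true size is known only as a minimum.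

Compound 3 `COc1cc(-c2cc(/C=C/C(=O)c3ccc(F)c(F)c3)[nH]n2)cc(OC)c1OC` is not yet measured. It differs from compound 2 by 3,4-difluorophenyl in place of 3,4-dimethoxyphenyl on a carbonyl carbon. For the measured compounds named here, the measured step sits at this same carbonyl carbon and shows that the aryl group there can shift this assay by a large amount; it says nothing directly about 3,4-difluorophenyl, since the only aryl groups with results are 4-aminophenyl and 3,4-dimethoxyphenyl. With the two hydrogen-bond acceptors of the dimethoxy group leaving, a move toward higher numbers in this assay is expected for compound 3, a 2.3-fold higher number from compound 2 to compound 3 (0.36 log units; beyond the scatter), of uncertain size and possibly within the scatter. Compound 3 is estimated at 15000 nM, with a range of 3000 nM to 80000 nM.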

Compound 3, concentration lethal to 50% of the cells: > 100000 nM
Compound 3: only a limit was reported; the forecaster's own chance of this, stated with the estimate: 25%; middle value at least 6.6-fold (0.82 log units) from the limit.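

In this assay, the carbonyl carbon now carries a second aryl change away from 3,4-dimethoxyphenyl: 3,4-difluorophenyl in its place gives an at least 15-fold higher number from compound 2 to compound 3 (1.18 log units; beyond the scatter). Compound 3 reaches only a limit of the assay, > 100000 nM, so 3,4-dimethoxyphenyl is the only one of the three aryl groups here that gives a number, and the loss of that number is no longer tied to 4-aminophenyl alone. The step just given is a minimum, and the step from compound 1 to compound 3 cannot be read, because the two compounds share the same end of the range: the limit of > 100000 nM in this assay, at which 2 of the 3 values shown sit.

Going by these compounds, whether the result at this position needs both methoxy groups stays open, and a plain phenyl or a phenyl carrying a single methoxy group would separate the two cases. Also open, on these data alone, is whether 4-aminophenyl and 3,4-difluorophenyl differ from each other at all in this test, and whether larger ethoxy groups in place of the methoxy groups would keep a numeric result.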